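Trading one fluorinated benzyl group for another

The compounds below may be only part of what the source reports. "The series", "measured", "known", "first", "only" and "open" are said of these compounds alone.

In a functional assay on HCT-116 cells (Homo sapiens) for cytotoxicity, read by sulforhodamine B assay (on this read-out lower numbers stand for stronger inhibition of growth and higher numbers for weaker inhibition of growth), compound 1 (`N#Cc1ccc(COC[C@H]2O[C@@H](n3c(NCc4ccc5ncccc5c4)nc4c(N)ncnc43)[C@H](O)[C@@H]2O)cc1`) gives > 80000 nM as a limit of the assay and not as a number. Within the data shown here, compound 2 (`Nc1ncnc2c1nc(NCc1ccc3ncccc3c1)n2[C@@H]1O[C@H](COCc2cc(F)c(F)c(F)c2)[C@@H](O)[C@H]1O`) gives 18000 nM and so holds the only true number so far. Among the measured compounds shown here, the single measured step (an at least 4.4-fold lower number from compound 1 to compound 2 (0.64 log units; beyond the scatter)) put 3,4,5-trifluorophenyl in place of 4-cyanophenyl on a saturated chain carbon bound to an oxygen on a saturated carbon, which shows that changes at this place can move the number.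

Compound 3 (`Nc1ncnc2c1nc(NCc1ccc3ncccc3c1)n2[C@@H]1O[C@H](COCc2ccc(C(F)(F)F)cc2)[C@@H](O)[C@H]1O`) changes the same place again (4-(trifluoromethyl)phenyl in place of 3,4,5-trifluorophenyl on a saturated chain carbon bound to an oxygen on a saturated carbon), with 4-(trifluoromethyl)phenyl in place of 3,4,5-trifluorophenyl. The earlier step removed a ring bearing a nitrile, whereas here one fluorinated ring replaces another, so that step is only a loose guide and gives no direction. The expectation therefore stays close to compound 2 at 18000 nM in this assay as the starting point. The expected change (a 1.1-fold higher number from compound 2 to compound 3 (0.05 log units; within the scatter)) is small and probably within the scatter. Compound 3 is estimated at 20000 nM in a range from 8000 nM to 50000 nM (an estimate, not a measurement).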

Compound 3, concentration for 50% growth inhibition: 27000 nM
Estimate against measurement, compound 3: 1.4-fold (0.13 log units) below, within the range that was stated.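

Replacing one fluorinated ring with another gives a 1.5-fold higher number from compound 2 to compound 3 (0.18 log units; within the scatter), so in this assay the 3,4,5-trifluorobenzyl and 4-(trifluoromethyl)benzyl groups cannot be told apart, and this position tolerates this particular swap. The second new comparison gives an at least 2.9-fold lower number from compound 1 to compound 3 (0.47 log units; beyond the scatter), so two different fluorinated benzyl groups, rather than just one, now separate clearly from the 4-cyanophenyl compound, which makes the earlier shift look less like a quirk of a single ring. Compound 1 stands at a limit of the assay and not at a number, so both steps that start from it give only a minimum size, and the true gap stays unknown: the limit of > 80000 nM in this assay, at which 1 of the 3 values shown sits.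

How a plain benzyl group or a 4-methoxybenzyl group would read at this position remains open, so the compounds shown cannot say whether fluorine matters in itself or whether losing the cyano group is enough. The data also give no reason for the gap between the cyano compound and the two fluorinated compounds, and they cover only this one cell line.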